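Acid-to-amide step in a diaryl pyridine ether series

A few compounds are considered here, and "the series" means these few. Any claim that something is new, unique, unknown or untested is made for them only; others in the source may bear on it.

Compound 2 `CC(CCCCOc1cc(-c2ccccc2)cc(-c2ccccc2)n1)C(=O)O` holds the lowest number of the pair so far: in an assay on cell membranes from spleen (Cavia porcellus) for binding affinity to leukotriene B4 receptor 1 (Homo sapiens) (a higher number here means a weaker inhibitor, a lower number a stronger inhibitor), compound 2 gives 4 nM. Compound 1 `O=C(O)CCCCOc1cc(-c2ccccc2)cc(-c2ccccc2)n1` gives 50 nM, and the step of a 13-fold lower number from compound 1 to compound 2 (1.10 log units; beyond the scatter) is the only one in hand. Compound 3 `NC(=O)CCCCCOc1cc(-c2ccccc2)cc(-c2ccccc2)n1` differs from compound 2 by carbamoylmethyl in place of 1-carboxyethyl on a saturated chain carbon, four bonds along the chain from an oxygen on an aromatic ring. Among the compounds with values here, no measured step covers the exchange of an acid for an amide; the known step only shows that the 1-carboxyethyl end carries weight, so a move away from it is expected to raise the number. Compound 3 is therefore estimated at 250 nM, range 40 nM to 1500 nM, a step of a 63-fold higher number from compound 2 to compound 3 (1.80 log units; beyond the scatter) expected to lie beyond the scatter.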

Compound 3, half-maximal inhibitory concentration: 160 nM
The estimate for compound 3 lay 1.6-fold (0.19 log units) above the measured number, within the range that was stated.
By their numbers in this assay, from the lowest: compound 2; then compound 1; then compound 3.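

In this assay the carbamoylmethyl end gives up nearly all of what the 1-carboxyethyl end gained (a 40-fold higher number from compound 2 to compound 3 (1.60 log units; beyond the scatter)). It also sits above the plain carboxy end (a 3.2-fold higher number from compound 1 to compound 3 (0.51 log units; beyond the scatter)), so this position tolerates neither replacement of the acid end as well as it tolerates the acids themselves. Each step changes more than the acid-to-amide exchange alone, and nothing measured explains the rise.

Open, on these data alone, is whether an unbranched carboxylic acid of the same chain length as compound 3 would hold a low number. Also open, as far as these compounds go, is how a methyl ester or a tetrazole would behave at this chain end.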